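The compounds below may be only part of what the source reports. "The series", "measured", "known", "first", "only" and "open" are said of these compounds alone.

Measured compounds:
compound 1 `CS(=O)(=O)c1ccc(N2N=C(c3ccc(Br)cc3)CCC2=O)cc1` with 10% in a functional assay on the whole organism (strain Wistar) for inhibition, with Rattus norvegicus as the target, read by paw edema, with stated times of 30 min and 3 h, at a dose of 0.05 mmol/kg by the oral route; a higher number here means more inhibition at the dose given (going by the name of the read-out), a lower number less inhibition
compound 2 `CS(=O)(=O)c1ccc(N2N=C(c3ccc(Oc4ccccc4)cc3)CCC2=O)cc1` with 50% in this assay

Compound 2 gives the higher of the two numbers in this assay; the step of a number 40 percentage points higher from compound 1 to compound 2 (beyond the scatter) lies beyond the scatter. Compound 3 `CC(C)(C)c1ccc(C2=NN(c3ccc(S(C)(=O)=O)cc3)C(=O)CC2)cc1` differs from compound 2 by tert-butyl in place of phenoxy on an aromatic carbon. Going by the values given here, only the step from compound 1 to compound 2 bears on this change, and it shows the phenoxy group well above bromo; tert-butyl is neither, so for compound 3 a moderate fall is expected, a number 15 percentage points lower from compound 2 to compound 3 (beyond the scatter), in this assay. Compound 3 is estimated at 35%, with a range from 10% to 60%.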

Compound 3, a percentage reported as inhibition, in the whole organism at one dose (the size of the read-out at that dose, not a potency): 50%
The estimate for compound 3 lay 15 percentage points below the measured number; the measured number falls inside the stated range.
By their numbers in this assay, from the lowest: compound 1; then compounds 2 and 3 (each within the scatter of the next).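

In this assay, the change from phenoxy to tert-butyl gives no change at the digits printed from compound 2 to compound 3 (within the scatter). Among these compounds, then, an aromatic ring and an oxygen in the group on this aromatic carbon are not needed to stay clear of bromo, since tert-butyl has neither and still gives a number 40 percentage points higher from compound 1 to compound 3 (beyond the scatter). Nothing available explains why these two different groups read alike. From the compounds shown here alone, it remains open whether an amine, a carboxylic acid or a longer chain at this carbon would match them, and whether compound 2 and compound 3 would also read alike at other doses.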